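Cytotoxicity Expected for a Methoxycarbonyl Analogue

The compounds below may be only part of what the source reports. "The series", "measured", "known", "first", "only" and "open" are said of these compounds alone.

Compound 1, `COCCNc1nc(F)c(-c2nn(Cc3ccc(C#N)cc3)c(=O)c3ccccc23)cc1Cl`, gave only an assay limit: > 100000 nM.
Compound 2, `Cc1cc(-c2ccc(F)nc2F)nn(Cc2ccc(Cl)cc2)c1=O`, gave 83800 nM.
Compound 3, `N#Cc1ccc(Cn2nc(-c3cc(Cl)c(NCC(O)CO)nc3F)c3ccccc3c2=O)cc1`, gave only an assay limit: > 100000 nM.

These three were tested in an ADME assay on HepG2 2.2.15 cells (Homo sapiens) for cytotoxicity, read by MTT assay, with a stated time of 8 days; on this read-out lower numbers stand for higher toxicity in this test and higher numbers for lower toxicity in this test. Among the compounds with values here, compound 2 stands as the only true number among the three; the other two values are limits of the assay. The step that the two limits leave unreadable from compound 1 to compound 3 cannot be read, since both ends sit at the limit of > 100000 nM in this assay, at which 2 of the 3 values shown sit.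

Compound 4, `COC(=O)c1cc(-c2ccc(F)nc2F)nn(Cc2ccc(Cl)cc2)c1=O`, differs from compound 2 by methoxycarbonyl in place of methyl on an aromatic carbon. Within the data shown here, no measured step touches this position, so no reading of the effect exists. The expectation for compound 4 is therefore no step beyond the scatter, a 1.1-fold higher number from compound 2 to compound 4 (0.03 log units; within the scatter). Compound 4 is estimated in this assay at 90000 nM, with a range from 40000 nM to 200000 nM.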

Compound 4, half-maximal cytotoxic concentration: > 100000 nM
Compound 4 gave a limit, no number (the forecaster's own chance of this, stated with the estimate: 50%); middle value at least 1.1-fold (0.04 log units) away from the limit.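

Placing methoxycarbonyl in place of methyl on this aromatic carbon gives an at least 1.1-fold higher number from compound 2 to compound 4 (0.07 log units; that floor lies within the scatter), so the larger group brings no sign of higher toxicity in this assay. Compound 4 gives a limit and not a number: the limit of > 100000 nM in this assay, at which 3 of the 4 values shown sit. Within the data shown here, the true size of the step therefore remains unknown, and this is the first reading at this position.

Going by these compounds, whether a carboxylic acid, an amine or a longer chain on this carbon would give a lower number remains open. So does whether the same change would behave alike on the core of compound 1.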